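The compounds below may be only part of what the source reports. "The series", "measured", "known", "first", "only" and "open" are said of these compounds alone.

In a functional assay on HeLa cells (Homo sapiens) for antiproliferative activity, read by CCK-8 assay, with a stated time of 72 h, tested at 8 uM (on this read-out lower numbers stand for a weaker effect and higher numbers for a stronger effect at the one concentration tested), compound 1 `Nc1ccccc1NC(=O)c1ccc(CSC(=S)N2CCc3ccccc32)cc1` gives 67% and compound 2 `Nc1ccccc1NC(=O)c1ccc(CSC(=S)N2CCc3cc(Cl)ccc32)cc1` gives 65.1%. Compound 2 stands with compound 1 within the scatter, as the step of a number 1.9 percentage points lower from compound 1 to compound 2 (within the scatter) shows. Compound 3 `CCN(Cc1ccncc1)C(=S)SCc1ccc(C(=O)Nc2ccccc2N)cc1` differs from compound 2 in one place: ethyl((pyridin-4-yl)methyl)amino in place of 5-chloro-2,3-dihydro-1H-indol-1-yl on a thiocarbonyl carbon. Going by the values given here, only one measured step exists, and it concerns a chloro in place of hydrogen on an aromatic carbon of the group that leaves here, so it bears on this change only loosely; it was small, a number 1.9 percentage points lower from compound 1 to compound 2 (within the scatter). Nothing measured speaks to replacing the whole 5-chloro-2,3-dihydro-1H-indol-1-yl at the thiocarbonyl carbon with ethyl((pyridin-4-yl)methyl)amino, so no step beyond the scatter is expected in either direction, though the range must be wide. The expected step is a number 3.1 percentage points lower from compound 2 to compound 3 (within the scatter). Compound 3 is therefore estimated at 62%, between 45% and 78%.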

Compound 3, a percentage reported as inhibition, at one concentration (the size of the read-out at that concentration, not a potency): 77.7%
Compound 3: middle estimate off by 15.7 percentage points, on the low side, and the stated range covers the measured number.
By their numbers in this assay, from the lowest: compounds 2 and 1 (each within the scatter of the next); then compound 3.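

At the thiocarbonyl carbon, replacing the whole group moves the number in this assay beyond the scatter: ethyl((pyridin-4-yl)methyl)amino in place of 5-chloro-2,3-dihydro-1H-indol-1-yl gives a number 12.6 percentage points higher from compound 2 to compound 3 (beyond the scatter), and in place of 2,3-dihydro-1H-indol-1-yl it gives a number 10.7 percentage points higher from compound 1 to compound 3 (beyond the scatter). The earlier chloro change on the leaving group, a number 1.9 percentage points lower from compound 1 to compound 2 (within the scatter), had shown no such movement, so this position responds to an exchange of the whole group, here upward from both starting compounds. Nothing available explains the rise.

Going by these compounds, whether the step follows the ethyl or the (pyridin-4-yl)methyl part of the entering group stays open, since the two arrive together. On these data alone, how a methyl in place of the ethyl, or a morpholin-4-yl at the thiocarbonyl carbon, would read also remains open.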